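This account rests on a few compounds, and the source may have more. Where it says the series, first, only, none or still open, it means among the compounds named here.

In a functional assay (blood) for inhibition, with Homo sapiens as the target (on this read-out higher numbers stand for weaker inhibition and lower numbers for stronger inhibition), compound 3 (`N#Cc1cc(-c2ccoc2)c2ccc(OCc3cccc(C4(O)CCOCC4)c3)cc2c1`) has the lowest of the three measured numbers at 10 nM, ahead of compound 1 (`N#Cc1cc(-c2ccccc2)c2ccc(OCc3cccc(C4(O)CCOCC4)c3)cc2c1`) at 100 nM and compound 2 (`Cn1nnc(-c2cc(-c3ccccc3)c3ccc(OCc4cccc(C5(O)CCOCC5)c4)cc3c2)n1`) at 310 nM. Compound 4 (`OC1(c2cccc(COc3ccc4c(-c5ccoc5)cc(Cc5nccs5)cc4c3)c2)CCOCC1`) keeps the furan-3-yl group of compound 3 but has (1,3-thiazol-2-yl)methyl in place of cyano on an aromatic carbon.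

The only measured replacement of cyano is a 3.1-fold higher number from compound 1 to compound 2 (0.49 log units; beyond the scatter), with 2-methyl-2H-tetrazol-5-yl as the incoming group. This modest step goes towards weaker inhibition, but it was measured with phenyl rather than furan-3-yl in the molecule. The other step, a 10-fold lower number from compound 1 to compound 3 (1.00 log units; beyond the scatter), is the change of phenyl to furan-3-yl, which compound 3 already contains, so it gives no direct guide to the cyano replacement. For the measured compounds named here, no measured compound carries the (1,3-thiazol-2-yl)methyl group, so the expectation rests on a single precedent.

A modest rise in this assay is expected, and the estimated step is a 2.5-fold higher number from compound 3 to compound 4 (0.40 log units; beyond the scatter). Compound 4 is expected at 25 nM, with an estimated range of 8 nM to 80 nM.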

Compound 4, half-maximal inhibitory concentration: 660 nM
Estimate against measurement, compound 4: 26-fold (1.42 log units) below; measured number above the stated range.
By their numbers in this assay, from the lowest: compound 3; then compound 1; then compound 2; then compound 4.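

At the cyano position of the furan-3-yl series, this assay shows a large penalty for (1,3-thiazol-2-yl)methyl, with a 66-fold higher number from compound 3 to compound 4 (1.82 log units; beyond the scatter). Together with a 3.1-fold higher number from compound 1 to compound 2 (0.49 log units; beyond the scatter), this gives two replacements of cyano on two backgrounds, and both move towards weaker inhibition, so the position does not tolerate either incoming group without loss. Nothing on hand accounts for the size of the new step.

The compounds shown leave open whether the loss follows the thiazole ring or its methylene link, which a directly attached 1,3-thiazol-2-yl group would separate, and whether the background contributes, which 2-methyl-2H-tetrazol-5-yl alongside furan-3-yl would test. On these data alone, whether any replacement can match cyano also remains open, for instance a small group such as methyl, chlorine or a primary amide.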